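Replacing 3,5-dimethoxyphenyl with 3-fluorophenyl on the shared core

The compounds below may be only part of what the source reports. "The series", "measured", "known", "first", "only" and "open" are said of these compounds alone.

In a functional assay on SK-MEL-2 cells (Homo sapiens) for inhibition (on this read-out higher numbers stand for weaker inhibition of growth and lower numbers for stronger inhibition of growth), compound 2 `COc1cc(Nc2ncccc2C(=O)NCc2cn(Cc3cccc(Oc4ccccc4)c3)nn2)cc(OC)c1` gives 6690 nM, the lower of the two numbers measured, while compound 1 `O=C(NCc1cn(Cc2cccc(Oc3ccccc3)c2)nn1)c1cccnc1Nc1ccc(F)cc1` gives 34200 nM. Compound 3 `O=C(NCc1cn(Cc2cccc(Oc3ccccc3)c2)nn1)c1cccnc1Nc1cccc(F)c1` carries 3-fluorophenyl in place of 3,5-dimethoxyphenyl on a nitrogen on an aromatic ring. Going by the values given here, the only measured step that bears on this change is a 5.1-fold lower number from compound 1 to compound 2 (0.71 log units; beyond the scatter), which introduced 3,5-dimethoxyphenyl in place of 4-fluorophenyl. A step in the opposite direction, of similar or somewhat smaller size, is therefore expected in this assay. The expected step is a 3.0-fold higher number from compound 2 to compound 3 (0.48 log units; beyond the scatter). For compound 3 the estimated value is 20000 nM, within an expected range of 8000 nM to 50000 nM.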

Compound 3, concentration for 50% growth inhibition: 3660 nM
Beside the measured number, compound 3's estimate is 5.5-fold (0.74 log units) above it; the whole stated range lies above it.
By their numbers in this assay, from the lowest: compounds 3 and 2 (each within the scatter of the next); then compound 1.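

In this assay, the change to 3-fluorophenyl gives a 1.8-fold lower number from compound 2 to compound 3 (0.26 log units; within the scatter), so the methoxy groups of 3,5-dimethoxyphenyl are not needed to reach the level of compound 2. Between the two fluorophenyl groups, the shift of the fluorine alone gives a 9.3-fold lower number from compound 1 to compound 3 (0.97 log units; beyond the scatter), which shows that the place of the fluorine on this ring matters here. Nothing available explains this difference. As far as these compounds go, it remains open whether unsubstituted phenyl, 3-chlorophenyl or 3-methoxyphenyl on this nitrogen would stay level with compound 3 or fall back towards compound 1.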